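From trifluoromethoxy to hydroxy on the shared core

The source may hold more compounds than are shown below. What is called first, only, known or untested is meant among the compounds shown, and "the series" means these compounds.

Compound 1 `FC(F)(F)c1ccc(-c2ccc(-c3ccc(-c4nc5ccccc5[nH]4)cc3)cc2)cc1`: 100000 nM
Compound 2 `FC(F)(F)Oc1ccc(-c2ccc(-c3ccc(-c4nc5ccccc5[nH]4)cc3)cc2)cc1`: 100000 nM

In a functional assay on DWD cells (Homo sapiens) for inhibition, read by sulforhodamine B assay (a lower number here means a stronger inhibitor of growth, a higher number a weaker inhibitor of growth), compound 2 gives 100000 nM, level with compound 1 at the digits shown. Compound 3 `Oc1ccc(-c2ccc(-c3ccc(-c4nc5ccccc5[nH]4)cc3)cc2)cc1` differs from compound 2 by one change: hydrogen in place of trifluoromethyl on an oxygen on an aromatic ring. This turns trifluoromethoxy to hydroxy. Among the compounds with values here, only one measured step bears on it, no change at the digits printed from compound 1 to compound 2 (within the scatter), and that step tests no hydroxy group, so the evidence is thin. Little or no change is therefore expected in this assay, if anything toward stronger inhibition of growth. The estimated step is a 2.0-fold lower number from compound 2 to compound 3 (0.30 log units; within the scatter). For compound 3 the expected value is 50000 nM, with an estimated range of 5000 nM to 100000 nM.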

Compound 3, concentration for 50% growth inhibition: 46300 nM
Compound 3: the middle estimate sits 1.1-fold (0.03 log units) above what was measured; the range from low to high includes it.
By their numbers in this assay, from the lowest: compound 3; then compounds 1 and 2 (each within the scatter of the next).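

In this assay, within the data shown here, the change to hydroxy is the first at this position to move the number beyond the scatter, with a 2.2-fold lower number from compound 2 to compound 3 (0.33 log units; beyond the scatter) and a 2.2-fold lower number from compound 1 to compound 3 (0.33 log units; beyond the scatter). Trifluoromethyl and trifluoromethoxy had stood level, so this position does respond to what is placed there, though only modestly here. Nothing measured here explains the step. The compounds shown leave open whether a methoxy group, an amine or a carboxylic acid at this position would shift the number further, and in which direction.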